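A Repeated Aryl Exchange, Now on a Second Core

A few compounds are considered here, and "the series" means these few. Any claim that something is new, unique, unknown or untested is made for them only; others in the source may bear on it.

In a functional assay on HeLa cells (Homo sapiens) for cytotoxicity, read by cell counting, with a stated time of 4 days (a higher number here means a weaker inhibitor, a lower number a stronger inhibitor), compound 2 `Nc1cccc(/C=C2\SC(=O)N(Cc3cccc(Cl)c3)C2=O)c1` gives 250000 nM, compound 1 `Nc1cccc(/C=C2\SC(=O)N(Cc3ccc(F)cc3)C2=O)c1` gives 86000 nM, and compound 3 `Nc1ccc(/C=C2\SC(=O)N(Cc3cccc(Cl)c3)C2=O)cc1` gives 24000 nM, the lowest of the three. Compound 1 differs from compound 2 by 4-fluorophenyl in place of 3-chlorophenyl on a saturated chain carbon bound to an amide-type nitrogen in a ring, and that change made a 2.9-fold lower number from compound 2 to compound 1 (0.46 log units; beyond the scatter). Compound 3 differs from compound 2 by 4-aminophenyl in place of 3-aminophenyl on a double-bonded chain carbon bound to a double-bonded ring carbon, which made a 10-fold lower number from compound 2 to compound 3 (1.02 log units; beyond the scatter). Compound 4 `Nc1ccc(/C=C2\SC(=O)N(Cc3ccc(F)cc3)C2=O)cc1` has not yet been measured in this assay; it differs from compound 3 by 4-fluorophenyl in place of 3-chlorophenyl on a saturated chain carbon bound to an amide-type nitrogen in a ring, the same change that carried compound 2 to compound 1. Resting on that single earlier step, compound 4 is expected to show a 2.7-fold lower number from compound 3 to compound 4 (0.43 log units; beyond the scatter) in this assay, a modest lowering of similar size, though one example cannot settle whether the step repeats on the core of compound 3. The estimate for compound 4 in this assay is 9000 nM, expected between 3500 nM and 25000 nM.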

Compound 4, half-maximal inhibitory concentration: 186000 nM
The estimate for compound 4 lay 21-fold (1.32 log units) below the measured number; measured number above the stated range.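

In this assay, the exchange of 3-chlorophenyl for 4-fluorophenyl did not carry over from one core to the other, giving a 7.8-fold higher number from compound 3 to compound 4 (0.89 log units; beyond the scatter), and the two instances point in opposite directions: the same change on two cores in this assay, a 2.9-fold lower number (0.46 log units; beyond the scatter) from compound 2 to compound 1 and a 7.8-fold higher number (0.89 log units; beyond the scatter) from compound 3 to compound 4, 23-fold (1.35 log units) apart, beyond the scatter of two such steps The exchange of 3-aminophenyl for 4-aminophenyl reverses in the same way, giving a 2.2-fold higher number from compound 1 to compound 4 (0.34 log units; beyond the scatter), and its two instances also disagree: the same change on two cores in this assay, a 10-fold lower number (1.02 log units; beyond the scatter) from compound 2 to compound 3 and a 2.2-fold higher number (0.34 log units; beyond the scatter) from compound 1 to compound 4, 23-fold (1.35 log units) apart, beyond the scatter of two such steps Across these four compounds, the outcome of each change depends on what stands at the other place, but with one pair per comparison this does not show why, or whether it holds beyond them.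

The compounds shown leave open whether the halogen or its place on the phenyl ring drives the reversal. A 4-chlorophenyl or 3-fluorophenyl group on the saturated chain carbon would separate the two.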